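The source may hold more compounds than are shown below. What is called first, only, known or untested is meant among the compounds shown, and "the series" means these compounds.

Of the compounds shown here, three sharing one core have been measured. Compound 1 `OC[C@]1(c2ccc(F)cc2)NC[C@H](O)[C@H]1O` gives 101000 nM in an assay on isolated protein for inhibition of lysosomal alpha-glucosidase (Rattus norvegicus), read by colorimetric assay; on this read-out higher numbers stand for weaker inhibition and lower numbers for stronger inhibition. Compound 2 `COc1cccc([C@]2(CO)NC[C@@H](O)[C@@H]2O)c1` gives 52000 nM in this assay. Compound 3 `OC[C@]1(c2c(F)c(F)c(F)c(F)c2F)NC[C@H](O)[C@H]1O` gives 183000 nM in this assay, the highest of the three numbers; its gap to compound 1 lies within the usual scatter, while its gap to compound 2 lies beyond it. Compound 4 `OC[C@@]1(c2c(F)c(F)c(F)c(F)c2F)NC[C@@H](O)[C@@H]1O` has not yet been measured. (the two compounds have the same atoms and bonds and differ only in configuration as drawn: 3 of 3 stereo elements differ (all stereocentres are inverted: mirror images); a stereocentre at a saturated ring carbon is drawn S in compound 3 and R in compound 4; a stereocentre at a saturated ring carbon is drawn S in compound 3 and R in compound 4; a stereocentre at a saturated ring carbon is drawn S in compound 3 and R in compound 4). Among the measured compounds shown here, no measured pair in this set shows what inverting every stereocentre does, so the expected step in this assay is small, with no clear direction and likely not beyond the scatter: a 1.4-fold higher number from compound 3 to compound 4 (0.14 log units; within the scatter). Compound 4 is therefore estimated at 250000 nM, in a range from 60000 nM to 1000000 nM.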

Compound 4, half-maximal inhibitory concentration: 66000 nM
Compound 4: the middle estimate sits 3.8-fold (0.58 log units) above what was measured, within the range that was stated.
By their numbers in this assay, from the lowest: compounds 2, 4, 1 and 3 (each within the scatter of the next, the first and the last beyond it).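

Inverting all three stereocentres gives a 2.8-fold lower number from compound 3 to compound 4 (0.44 log units; beyond the scatter) in this assay, so configuration by itself can move the number beyond the scatter, which the earlier compounds, with no single-change pair among them, could not show. The step can be assigned to configuration alone because no atom or bond changes: the fact that compounds 3 and 4 differ only in the configuration as drawn

Going by these compounds, whether the same inversion would lower the number for the aromatic substituents of compound 1 or compound 2 stays open. Also open, on these data alone, is how a carboxylic acid or an amine on the aromatic ring would behave under this inversion.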